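Replacing diethylamino with 2-carboxypyrrolidin-1-yl on the shared core

A few compounds are considered here, and "the series" means these few. Any claim that something is new, unique, unknown or untested is made for them only; others in the source may bear on it.

In a functional assay on Caco-2 cells (Homo sapiens) for inhibition, read by MTT assay, with a stated time of 48 h, tested at 10 uM (a higher number here means more inhibition of growth at the concentration tested, a lower number less inhibition of growth), compound 1 (`CCN(CC)Cc1c(O)c([C@H]2CCN(C)C[C@H]2O)c2oc(C)cc(=O)c2c1O`) gives 17% in this read-out, and compound 2 (`Cc1cc(=O)c2c(O)c(CN3CCC(c4ccccc4)CC3)c(O)c([C@H]3CCN(C)C[C@H]3O)c2o1`) gives 21% in the same test. Within the data shown here, these two values lie within the usual scatter of each other, so compound 1 stands level with the only other compound measured.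

Compound 3 (`Cc1cc(=O)c2c(O)c(CN3CCCC3C(=O)O)c(O)c([C@H]3CCN(C)C[C@H]3O)c2o1`) still awaits its measurement. It keeps the core of compound 1 and carries 2-carboxypyrrolidin-1-yl in place of diethylamino on a saturated chain carbon bound to an aromatic carbon. Among the measured compounds shown here, the data hold no measured step for this replacement or for any other, so they fix neither its size nor its direction.

The expected change is none beyond the scatter, and the estimate is a step of a number 1 percentage points lower from compound 1 to compound 3 (within the scatter) with no firm direction. That expectation rests on compound 1 at 17% and compound 2 at 21% lying within the scatter of each other. In this assay the estimated value for compound 3 is 16% within an expected range from 5% to 28% in this test.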

Compound 3, percent growth inhibition at one concentration: 30%
For compound 3 the middle estimate is 14 percentage points below the measured one; the measured number lies above the stated range.
By their numbers in this assay, from the lowest: compounds 1, 2 and 3 (each within the scatter of the next, the first and the last beyond it).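

In this assay, among these compounds, the exchange of diethylamino for 2-carboxypyrrolidin-1-yl on a saturated chain carbon bound to an aromatic carbon gives the first step that can be read at this position, a number 13 percentage points higher from compound 1 to compound 3 (beyond the scatter), a modest one. It shows that the group at this place on the shared core can alter growth inhibition at the concentration tested, which the earlier pair of compounds, differing in more than a simple comparison could settle and lying within the scatter of each other, could not show. The entering group, with its five-membered non-aromatic ring and its carboxylic acid, is accepted here with a gain and no loss, but nothing measured accounts for the size or direction of this step.

The compounds shown do not separate what the ring contributes from what the carboxylic acid contributes, since both enter together in compound 3. Plain pyrrolidin-1-yl, or the methyl ester or primary amide in place of the carboxylic acid, would tell these apart, and the effect of the opposite configuration at the ring carbon carrying the acid also remains open.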